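Aminopyrimidine anilines: from a nitrile to a chlorophenyl group

The source may hold more compounds than are shown below. What is called first, only, known or untested is meant among the compounds shown, and "the series" means these compounds.

Compound 1 `CCOc1ccc(Br)cc1-c1cc(Nc2cccc(C#N)c2)nc(N)n1`: 720 nM
Compound 2 `Cc1ccc(Br)cc1-c1cc(Nc2ccc(Br)cc2)nc(N)n1`: 18 nM
Compound 3 `CCOc1ccc(Cl)cc1-c1cc(Nc2ccccc2Cl)nc(N)n1`: 4900 nM

Of the compounds shown here, three have been tested in an assay on Sf9 cells for inhibition of 1-acyl-sn-glycerol-3-phosphate acyltransferase beta (Homo sapiens); a lower number here means a stronger inhibitor, a higher number a weaker inhibitor. Compound 1 stands second highest of the three; compound 3 is nearest with a number beyond the scatter above it, and compound 2 lies furthest, well below it. Compound 4 `CCOc1ccc(Br)cc1-c1cc(Nc2ccc(Cl)cc2)nc(N)n1` has not yet been measured. It differs from compound 1 in one place: 4-chlorophenyl in place of 3-cyanophenyl on a nitrogen on an aromatic ring. Going by the values given here, no step between measured compounds is available for that change, and compound 2 differs from compound 1 in more than one place, so only its value can be compared. A step downward, beyond the scatter, is expected from compound 1 to compound 4 in this assay, a 4.8-fold lower number from compound 1 to compound 4 (0.68 log units; beyond the scatter). Compound 4 is estimated at 150 nM, between 30 nM and 700 nM.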

Compound 4, half-maximal inhibitory concentration: 16 nM
Beside the measured number, compound 4's estimate is 9.4-fold (0.97 log units) above it, outside the stated range (below it).
By their numbers in this assay, from the lowest: compounds 4 and 2 (each within the scatter of the next); then compound 1; then compound 3.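

In this assay, the group on this nitrogen proves to matter greatly: with the rest of the molecule unchanged, 4-chlorophenyl in place of 3-cyanophenyl gives a 45-fold lower number from compound 1 to compound 4 (1.65 log units; beyond the scatter), a large step. Going by these compounds alone, this is the first comparison here that isolates a single place, so a change of this size can be tied to this position alone. No measured evidence accounts for the step. Going by these compounds, it remains open whether the nitrile's loss or the chlorine's arrival drives the step, and how an unsubstituted phenyl, a methoxy group or an amine on that ring would compare.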